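The compounds below may be only part of what the source reports. "The series", "measured", "known", "first", "only" and "open" are said of these compounds alone.

Measured compounds in a functional assay on CHO-K1 cells for agonist activity at Glucose-dependent insulinotropic receptor (Homo sapiens), read by a luciferase reporter, with a stated time of 5 h; on this read-out higher numbers stand for an effect only at larger amounts of compound and lower numbers for an effect already at smaller amounts:
compound 1 `CC(C)OC(=O)N1CCC(COc2ccc(N3CCN(C(=O)c4ccco4)CC3)nc2)CC1` — 1900 nM
compound 2 `CCCS(=O)(=O)N1CCN(c2ccc(OCC3CCN(C(=O)OC(C)C)CC3)cn2)CC1` — 300 nM
compound 3 `COCCS(=O)(=O)N1CCN(c2ccc(OCC3CCN(C(=O)OC(C)C)CC3)cn2)CC1` — 300 nM

Compound 3 is level with compound 2 and, together with it, gives the lowest of the three numbers; the gap between them and the remaining compound is a 6.3-fold lower number from compound 1 to compound 3 (0.80 log units; beyond the scatter). Two steps from compound 1 replace the (furan-2-yl)carbonyl on the ring amine nitrogen with a sulfonyl group: a 6.3-fold lower number from compound 1 to compound 2 (0.80 log units; beyond the scatter) and a 6.3-fold lower number from compound 1 to compound 3 (0.80 log units; beyond the scatter). Between the two sulfonyl compounds, no change at the digits printed from compound 2 to compound 3 (within the scatter) shows that methoxy for methyl on the chain two bonds from the sulfonyl sulfur makes no difference.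

Compound 4 `CC(C)OC(=O)N1CCC(COc2ccc(N3CCN(S(=O)(=O)CC4CCCCC4)CC3)nc2)CC1` keeps the sulfonyl and differs from compound 3 by cyclohexyl in place of methoxymethyl on a saturated chain carbon bound to a sulfonyl sulfur. For the measured compounds named here, the only measured step at the sulfonyl substituent, no change at the digits printed from compound 2 to compound 3 (within the scatter), was within the scatter; no measured step places a ring on that carbon, so the exchange reaches further than anything covered. The expected step is no change at the digits printed from compound 3 to compound 4 (within the scatter), that is, nothing beyond the scatter, with the range kept wide for the untested ring. Compound 4 is estimated at 300 nM, range 100 nM to 1000 nM.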

Compound 4, half-maximal effective concentration: 90 nM
Beside the measured number, compound 4's estimate is 3.3-fold (0.52 log units) above it; measured number outside the range, below it.
By their numbers in this assay, from the lowest: compound 4; then compounds 2 and 3 (each within the scatter of the next); then compound 1.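

In this assay, cyclohexyl in place of methoxymethyl on a saturated chain carbon bound to a sulfonyl sulfur gives a 3.3-fold lower number from compound 3 to compound 4 (0.52 log units; beyond the scatter) and cyclohexyl in place of ethyl gives a 3.3-fold lower number from compound 2 to compound 4 (0.52 log units; beyond the scatter) so this position does respond to the substituent, which the within-scatter exchange of methoxy for methyl had not shown. Against the (furan-2-yl)carbonyl, (cyclohexylmethyl)sulfonyl gives a 21-fold lower number from compound 1 to compound 4 (1.32 log units; beyond the scatter) as the widest step in the series. No available evidence accounts for the change at this position.

From the compounds shown here alone, whether the ring itself matters or simply the larger group remains open, and an unbranched hexyl chain or a phenyl ring on the same carbon would separate the two. An amine on the ring at this position is equally untested by the compounds shown.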